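This account rests on a few compounds, and the source may have more. Where it says the series, first, only, none or still open, it means among the compounds named here.

Compound 1 `COc1cc(-c2nnc(SCC(=O)c3ccc(F)cc3)n2N)cc(OC)c1OC`. In a functional assay on PC-3 cells (Homo sapiens) for antiproliferative activity, read by MTT assay, with a stated time of 48 h (on this read-out higher numbers stand for weaker inhibition and lower numbers for stronger inhibition), compound 1 reaches only the assay limit, > 100000 nM.
Compound 2 `COc1cc(-c2nnc(SCC(=O)c3ccccc3F)n2N)cc(OC)c1OC`. In this assay compound 2 gives 43100 nM.
Compound 3 `COc1cc(-c2nnc(SCC(=O)Nc3ccc(C)cc3)n2N)cc(OC)c1OC`. In this assay compound 3 gives 43100 nM.

Compound 3 stands level with compound 2, the step of no change at the digits printed from compound 2 to compound 3 (within the scatter) lying within the scatter; compound 1 sits at the limit described by the limit of > 100000 nM in this assay, at which 1 of the 3 values shown sits, so the steps of an at least 2.3-fold lower number from compound 1 to compound 2 (0.36 log units; beyond the scatter) and an at least 2.3-fold lower number from compound 1 to compound 3 (0.36 log units; beyond the scatter) are known only as lower bounds. Compound 4 `COc1ccc(CNC(=O)CSc2nnc(-c3cc(OC)c(OC)c(OC)c3)n2N)cc1OC` carries 3,4-dimethoxybenzyl in place of 4-methylphenyl on an amide-type nitrogen. For the measured compounds named here, no measured step exchanges the substituent on the amide-type nitrogen, and the one change on that nitrogen's neighbourhood, no change at the digits printed from compound 2 to compound 3 (within the scatter), moved nothing beyond the scatter. The expectation for compound 4 is therefore a step of about a 1.1-fold lower number from compound 3 to compound 4 (0.03 log units; within the scatter), within the scatter. Compound 4 is estimated at 40000 nM, from 15000 nM to 100000 nM.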

Compound 4, half-maximal inhibitory concentration: > 100000 nM
Compound 4 was reported as a limit; the forecaster's own chance of this, stated with the estimate: 25%; middle value at least 2.5-fold (0.39 log units) away from the limit.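

The substituent on the amide-type nitrogen is not silent: 3,4-dimethoxybenzyl in place of 4-methylphenyl gives an at least 2.3-fold higher number from compound 3 to compound 4 (0.36 log units; beyond the scatter). In this assay compound 4 gives > 100000 nM, which is a limit and not a number. The full size of the step therefore stays unknown: the limit of > 100000 nM in this assay, at which 2 of the 4 values shown sit.

The compounds shown do not separate the benzyl carbon from the two methoxy groups as the source of this step. Going by these compounds, an unsubstituted benzyl or a 4-methoxyphenyl on the same nitrogen would separate them, and a carboxylic acid on that ring remains open.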